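Aryl sulfonyl swap on the shared core: compound 4

A few compounds are considered here, and "the series" means these few. Any claim that something is new, unique, unknown or untested is made for them only; others in the source may bear on it.

Compound 3 `CC1CCN(c2c(S(=O)(=O)c3ccc(F)c(Cl)c3)cnc3ccc(F)cc23)CC1` gives 95% in an assay on isolated protein for displacement of a labelled ligand from metabotropic glutamate receptor 5 (Homo sapiens), with a stated time of 60 min, tested at 1 uM (on this read-out higher numbers stand for more inhibition at the one concentration tested (going by the name of the read-out) and lower numbers for less inhibition), the largest of the three numbers shown, though the gap to compound 2 is within the usual scatter. Compound 2 `COc1ccc(S(=O)(=O)c2cnc3ccc(F)cc3c2N2CCC(C)CC2)cc1` gives 85% in this assay, and the step of a number 10 percentage points higher from compound 2 to compound 3 (within the scatter) is within the scatter. Compound 1 `CC1CCN(c2c(S(=O)(=O)c3cc(Cl)cc(Cl)c3)cnc3ccc(F)cc23)CC1` gives 69% in this assay; the steps of a number 26 percentage points higher from compound 1 to compound 3 (beyond the scatter) and a number 16 percentage points higher from compound 1 to compound 2 (beyond the scatter) are both beyond the scatter, so the aryl group on the sulfonyl sulfur does move the read-out.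

Compound 4 `Cc1ccc(S(=O)(=O)c2cnc3ccc(F)cc3c2N2CCC(C)CC2)cc1F` carries the change (3-fluoro-4-methylphenyl in place of 3-chloro-4-fluorophenyl on a sulfonyl sulfur). Both measured steps on this position bear on it: one was modest, the other within the scatter. The new group is again a small, neutral six-membered aromatic ring of carbon only, so no step beyond the scatter is expected; the step of a number 7 percentage points lower from compound 3 to compound 4 (within the scatter) is estimated to stay within it, with a slight downward lean. Compound 4 is therefore expected to give 88% in this assay, within a range from 72% to 98%.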

Compound 4, a percentage reported as inhibition, at one concentration (the size of the read-out at that concentration, not a potency): 86%
The estimate for compound 4 lay 2 percentage points above the measured number; measured number inside the range.
By their numbers in this assay, from the lowest: compound 1; then compounds 2, 4 and 3 (each within the scatter of the next).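

In this assay, the step of a number 9 percentage points lower from compound 3 to compound 4 (within the scatter) shows that the chlorine of 3-chloro-4-fluorophenyl is not required to keep the number within the scatter at this sulfonyl sulfur, and the step of a number 1 percentage points higher from compound 2 to compound 4 (within the scatter) leaves 3-fluoro-4-methylphenyl and 4-methoxyphenyl unseparated as well. With the step of a number 17 percentage points higher from compound 1 to compound 4 (beyond the scatter) a third aryl group now stands clear of 3,5-dichlorophenyl, so among these four compounds only that group lies apart, while the other three cannot be ordered on this read-out. No measurement at hand explains these differences.

A single-concentration read-out also leaves open whether potency differs among compounds 2, 3 and 4. As far as these compounds go, whether a pyridyl ring or an aminophenyl group on the sulfonyl sulfur would hold the number also remains open.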